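Amide to urea on an inactive pyrazole scaffold

The compounds below may be only part of what the source reports. "The series", "measured", "known", "first", "only" and "open" are said of these compounds alone.

Compound 1 `COc1cc(-c2nn(-c3cccc(NC(=O)c4cccc(C(F)(F)F)c4)c3)cc2-c2ccncc2)ccc1Cl`: > 50000 nM
Compound 2 `COc1cc(-c2nn(-c3cccc(NC(=O)c4ccc(Cl)c(C(F)(F)F)c4)c3)cc2-c2ccncc2)ccc1Cl`: > 32500 nM

In a functional assay on Hs-578T cells (Homo sapiens) for inhibition, read by sulforhodamine B assay, with a stated time of 48 h (a lower number here means a stronger inhibitor of growth, a higher number a weaker inhibitor of growth), compound 1 reaches only a limit of the assay, > 50000 nM. Compound 2, with chloro in place of hydrogen on an aromatic carbon, likewise gives only a limit in this assay, > 32500 nM. Going by the values given here, the one measured step, a step that the two limits leave unreadable from compound 1 to compound 2, therefore cannot be read, since both ends sit at limits (the limit of > 32500 nM in this assay, at which 1 of the 2 values shown sits, (the limit of > 50000 nM in this assay, at which 1 of the 2 values shown sits)). Compound 2 thus stands nowhere definite: it is simply inactive up to the concentration tested.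

Compound 3 `COc1cc(-c2nn(-c3cccc(NC(=O)Nc4ccc(Cl)c(C(F)(F)F)c4)c3)cc2-c2ccncc2)ccc1Cl` differs from compound 2 by (4-chloro-3-(trifluoromethyl)phenyl)amino in place of 4-chloro-3-(trifluoromethyl)phenyl on a carbonyl carbon, turning the amide into a urea. Among the compounds with values here, no measured step bears on this change. With both neighbours inactive, compound 3 is expected to remain inactive too, an estimated step that the limit leaves unreadable from compound 2 to compound 3, giving an expected value of 40000 nM, with a range from 8000 nM to 100000 nM.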

Compound 3, concentration for total growth inhibition: 18300 nM
Compound 3: middle estimate off by 2.2-fold (0.34 log units), on the high side; low and high end bracket the measured number.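

Going by these compounds alone, compound 3 is the first compound here to give a measured number rather than a limit in this assay, so (4-chloro-3-(trifluoromethyl)phenyl)amino on the carbonyl carbon brings growth inhibition into a readable range. Against the amide that carries the same aromatic ring, the change gives an at least 1.7-fold lower number from compound 2 to compound 3 (0.24 log units; that floor lies within the scatter), and the size of this step is bounded by a limit: the limit of > 32500 nM in this assay, at which 1 of the 3 values shown sits. Against compound 1, the change of the whole group on the carbonyl carbon gives an at least 2.7-fold lower number from compound 1 to compound 3 (0.43 log units; beyond the scatter), so only this comparison clears the usual scatter.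

From the compounds shown here alone, it remains open whether the urea would hold this level of inhibition without the chloro on its aromatic ring. Going by these compounds, it is also open whether the urea's hydrogen matters, which a methyl on that nitrogen or an oxygen in its place could test.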